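This account rests on a few compounds, and the source may have more. Where it says the series, first, only, none or still open, it means among the compounds named here.

The three compounds measured so far in a functional assay on HepG2 cells (Homo sapiens) for cytotoxicity, read by MTT assay, with a stated time of 72 h (on this read-out higher numbers stand for weaker inhibition and lower numbers for stronger inhibition), are:

Compound 1, `CN1[C@@H]2c3[nH]c4ccccc4c3C[C@H]1[C@H](C#N)N1[C@@H](CNC(=O)c3cccc(C(F)(F)F)c3)c3[nH]c4ccccc4c3C[C@@H]21`, with 340 nM
Compound 2, `CN1[C@@H]2c3[nH]c4ccccc4c3C[C@H]1[C@H](C#N)N1[C@@H](CNC(=O)c3ccc4ccccc4c3)c3[nH]c4ccccc4c3C[C@@H]21`, with 1210 nM
Compound 3, `CN1[C@@H]2c3[nH]c4ccccc4c3C[C@H]1[C@H](C#N)N1[C@@H](CNC(=O)c3cc4ccccc4[nH]3)c3[nH]c4ccccc4c3C[C@@H]21`, with 440 nM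

All three share one core and differ only in the group attached to the carbonyl carbon of the amide. Compound 3 gives the second highest number of the three; its nearest neighbour is compound 1, and a 1.3-fold higher number from compound 1 to compound 3 (0.11 log units; within the scatter), so the two cannot be told apart. Compound 2 lies further off: a 2.8-fold lower number from compound 2 to compound 3 (0.44 log units; beyond the scatter). The widest swing across this group, a 3.6-fold higher number from compound 1 to compound 2 (0.55 log units; beyond the scatter), is still modest.

Compound 4, `COc1ccc(/C=C/C(=O)NC[C@H]2c3[nH]c4ccccc4c3C[C@H]3[C@H]4c5[nH]c6ccccc6c5C[C@@H]([C@H](C#N)N23)N4C)cc1`, repeats the same kind of exchange at the same place: 2-(4-methoxyphenyl)ethenyl in place of 1H-indol-2-yl on a carbonyl carbon. The three measured steps at this position all bear on it and none exceeded a modest size, so the expected step of a 1.3-fold higher number from compound 3 to compound 4 (0.10 log units; within the scatter) is small, in either direction or none beyond the scatter. For compound 4 in this assay the estimate is 550 nM, with a range from 200 nM to 1500 nM.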

Compound 4, half-maximal inhibitory concentration: 2140 nM
Beside the measured number, compound 4's estimate is 3.9-fold (0.59 log units) below it; the measured number lies above the stated range.
By their numbers in this assay, from the lowest: compounds 1 and 3 (each within the scatter of the next); then compounds 2 and 4 (each within the scatter of the next).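

The group on the carbonyl carbon can move the number in this assay further than the first three compounds showed: the widest step is now a 6.3-fold higher number from compound 1 to compound 4 (0.80 log units; beyond the scatter), and the exchange made here gives a 4.9-fold higher number from compound 3 to compound 4 (0.69 log units; beyond the scatter). The same group set against naphthalen-2-yl gives a 1.8-fold higher number from compound 2 to compound 4 (0.25 log units; within the scatter), so compounds 2 and 4 now form a pair at the high end, while compounds 1 and 3 form a pair at the low end. The exchange from compound 3 swaps a hydrogen-bond donor for a hydrogen-bond acceptor and adds a double bond outside the aromatic rings, and these changes arrive together, so none can be singled out.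

Nothing available explains these steps. The compounds shown leave open how a 2-(4-methoxyphenyl)ethyl group, with the double bond gone, or a group carrying an amine would read here.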